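One Stereocentre Changed: Compound 3 and Compound 4

This account rests on a few compounds, and the source may have more. Where it says the series, first, only, none or still open, it means among the compounds named here.

Compound 1 `COc1ccc2c(c1)C=C1Cn3c-2c(C2CCCCC2)c2ccc(cc23)C(=O)NS(=O)(=O)N(C)CCCN(C)C1=O`: > 25000 nM
Compound 2 `COc1ccc2c(c1)C=C1Cn3c-2c(C2CCCCC2)c2ccc(cc23)C(=O)NS(=O)(=O)N(C)CCCCNC1=O`: > 25000 nM
Compound 3 `COc1ccc2c(c1)C[C@H]1Cn3c-2c(C2CCCCC2)c2ccc(cc23)C(=O)NS(=O)(=O)N(C)CCOCCN(C)C1=O`: > 25000 nM

In an ADME assay on Huh-7 cells (Homo sapiens) for cytotoxicity (a higher number here means that more compound is tolerated, a lower number that less compound is tolerated), compound 3 gives > 25000 nM, which is a limit of the assay and not a number. It shares this position with the other two measured compounds: the limit of > 25000 nM in this assay, at which 3 of the 3 values shown sit. None of the three therefore has an exact reading, and no order can be drawn among them.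

Compound 4 `COc1ccc2c(c1)C[C@@H]1Cn3c-2c(C2CCCCC2)c2ccc(cc23)C(=O)NS(=O)(=O)N(C)CCOCCN(C)C1=O` is the next structure to be tested. Its change from compound 3 is a small one: the two compounds have the same atoms and bonds and differ only in configuration as drawn: 1 of 1 stereo elements differ; a stereocentre at a saturated ring carbon is drawn S in compound 3 and R in compound 4. The two compounds have the same atoms and bonds, and a stereocentre at a saturated ring carbon is drawn S in compound 3 and R in compound 4.

Going by the values given here, no measured pair shows what such a change does here, so the expectation rests on the limit reached by the three measured compounds. The expected step that the limit leaves unreadable from compound 3 to compound 4 stays within the usual scatter, and another limit is the likeliest report.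

The estimated value for compound 4 is 30000 nM, with an expected range of 15000 nM to 60000 nM.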

Compound 4, half-maximal cytotoxic concentration: > 25000 nM
Compound 4 was reported as a limit; the forecaster's own chance of this, stated with the estimate: 85%; the middle value lies beyond the limit too.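

No step can be read between compound 3 and compound 4, because both were reported only as a limit and not as a number: the limit of > 25000 nM in this assay, at which 4 of the 4 values shown sit.

The compounds shown leave open how much of any of them the cells would tolerate beyond that limit, and so whether the configuration at the saturated ring carbon makes any difference.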